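Taking the Bromo Group off Compound 3

The source may hold more compounds than are shown below. What is called first, only, known or untested is meant among the compounds shown, and "the series" means these compounds.

In a functional assay on HepG2 cells (Mus musculus) for antiproliferative activity against HepG2 (Homo sapiens), read by MTT assay, with a stated time of 48 h (a higher number here means a weaker inhibitor, a lower number a stronger inhibitor), compound 1 (`COc1cc(/C=C/c2nnc(NC(=O)c3ccc(Cl)cc3)s2)c(Br)c(OC)c1OC`) gives 180 nM and compound 2 (`COc1cc(/C=C/c2nnc(NC(=O)c3cccc(F)c3)s2)c(Br)c(OC)c1OC`) gives 170 nM while compound 3 (`COc1cc(/C=C/c2nnc(NC(=O)c3cccc(O)c3)s2)c(Br)c(OC)c1OC`) gives 220 nM and these three values lie within the scatter of one another. Compound 4 (`COc1cc(/C=C/c2nnc(NC(=O)c3cccc(O)c3)s2)cc(OC)c1OC`) carries hydrogen in place of bromo on an aromatic carbon. The nearest measured steps (a 1.2-fold higher number from compound 1 to compound 3 (0.09 log units; within the scatter)) and (a 1.3-fold higher number from compound 2 to compound 3 (0.11 log units; within the scatter)) stay within the scatter, but they alter the group on the carbonyl carbon and leave the bromo untouched. Going by the values given here, no measured pair shows the loss of bromo, so the direction is open and no step beyond the scatter is expected in this assay. The estimated change is small (a 1.2-fold higher number from compound 3 to compound 4 (0.07 log units; within the scatter)). For compound 4 the expected value is 260 nM within an estimated range from 80 nM to 900 nM that stays wide.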

Compound 4, half-maximal inhibitory concentration: 260 nM
Beside the measured number, compound 4's estimate shows no gap at the digits printed; measured number inside the range.
By their numbers in this assay, from the lowest: compounds 2, 1, 3 and 4 (each within the scatter of the next).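

Going by these compounds alone, this pair is the first to change the aromatic carbon that carries the bromo, and in this assay hydrogen in place of bromo gives a 1.2-fold higher number from compound 3 to compound 4 (0.07 log units; within the scatter). With the 3-hydroxyphenyl group on the carbonyl carbon, the bromo can therefore be lost with no step beyond the scatter. No available evidence bears on this result.

The compounds shown leave open whether the same swap behaves alike with 4-chlorophenyl or 3-fluorophenyl on the carbonyl carbon. They also leave open what an amine or a carboxylic acid would do at this position.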